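The source may report more compounds than this note shows. Statements on the series, on what has been measured and on what is new or still open speak of the compounds shown alone.

Measured in a physicochemical assay for acid dissociation:
compound 1 `COc1ccc(Oc2ccc3c(NCCCNCc4cc(F)ccc4OC)ccnc3c2)cc1` gives 9.28
compound 2 `Fc1ccc(Cc2ccc3c(NCCCNCc4ccco4)ccnc3c2)c(Cl)c1` gives 9.47
compound 3 `COc1ccc(F)cc1CNCCCNc1ccnc2cc(Cc3ccc(F)cc3Cl)ccc12` gives 9.47

Compound 2 stands level with compound 3 at the digits given, the two together the highest of the three numbers; compound 3 is its nearest neighbour, no change at the digits printed from compound 2 to compound 3 (within the scatter), and compound 1 the furthest, though compound 1 still lies within the scatter of compound 2.

Compound 4 `Fc1ccc(Cc2ccc3c(NCCCNCc4ccco4)ccnc3c2)cc1` remains to be measured. Relative to compound 2 the change is hydrogen in place of chloro on an aromatic carbon. Within the data shown here, two measured steps bear on it, each swapping one aromatic group for another: a number 0.19 log units higher from compound 1 to compound 3 (within the scatter) and no change at the digits printed from compound 2 to compound 3 (within the scatter). Neither moved the acid dissociation constant beyond the scatter, so for the removal of a single chloro no step beyond the scatter is expected, no change at the digits printed from compound 2 to compound 4 (within the scatter). Compound 4 is therefore estimated at 9.47, within 9.2 to 9.75.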

Compound 4, acid dissociation constant: 9.47
Beside the measured number, compound 4's estimate shows no gap at the digits printed, and the stated range covers the measured number.
By their numbers in this assay, from the lowest: compounds 1, 2, 3 and 4 (each within the scatter of the next).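

In this assay, hydrogen in place of chloro gives no change at the digits printed from compound 2 to compound 4 (within the scatter). Where the earlier steps swapped whole groups, this one changes a single atom on an aromatic carbon, ortho to a large group and meta to a fluoro group, and the 4-fluorobenzyl and 2-chloro-4-fluorobenzyl compounds read alike. Nothing available explains this result.

Still open, from the compounds shown here alone, is whether an amine or a carboxylic acid at this place would move the number beyond the scatter. Also open, going by these compounds, is whether removing the chloro reads the same with 5-fluoro-2-methoxyphenyl in place of furan-2-yl.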